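The source may report more compounds than this note shows. Statements on the series, on what has been measured and on what is new or still open speak of the compounds shown alone.

In an ADME assay on MRC5 cells (Homo sapiens) for cytotoxicity, read by MTT assay, with a stated time of 72 h (on this read-out lower numbers stand for higher toxicity in this test and higher numbers for lower toxicity in this test), compound 3, `OC[C@H]1O[C@@H](n2cc(Cl)c3c(-c4ccoc4)ncnc32)[C@H](O)[C@@H]1O`, has no exact value, only a limit of > 50000 nM. Compound 2, `OC[C@H]1O[C@@H](n2cc(Cl)c3c(-c4ccco4)ncnc32)[C@H](O)[C@@H]1O`, is also reported only as a limit, > 50000 nM. Together they stand at the limit of > 50000 nM in this assay, at which 2 of the 3 values shown sit. Among the compounds with values here, the one measured step between close neighbours is a step that the two limits leave unreadable from compound 2 to compound 3, so it offers no size to carry forward.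

Compound 4, `OC[C@H]1O[C@@H](n2cc(Cl)c3c(-c4ccsc4)ncnc32)[C@H](O)[C@@H]1O`, is the next case. The change from compound 3 is thiophen-3-yl in place of furan-3-yl on an aromatic carbon. Within the data shown here, no measured step covers this exchange on the shared core.

The nearest guide is compound 1, `OC[C@H]1O[C@@H](n2cc(F)c3c(-c4ccsc4)ncnc32)[C@H](O)[C@@H]1O`, which also carries thiophen-3-yl, though its core is not identical, and which gives a real number of 50000 nM in this assay. On the strength of compound 1 at 50000 nM, a thiophen-3-yl compound is expected to sit close to the top of the measured range, and a large shift toward higher toxicity is not expected. Any movement would be modest and in that direction. The estimated change is an at least 1.1-fold lower number from compound 3 to compound 4 (0.04 log units; that floor lies within the scatter). Compound 4 is expected at about 45000 nM. Its estimated range runs from 12000 nM to 80000 nM.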

Compound 4, half-maximal cytotoxic concentration: > 50000 nM
Compound 4 ended at the assay's limit (the forecaster's own chance of this, stated with the estimate: 50%); middle value at least 1.1-fold (0.04 log units) away from the limit.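

In this assay compound 4 is reported only as a limit, > 50000 nM. Compound 2 and compound 3 are also limits, so the steps from each of them to compound 4 cannot be read, and furan-2-yl, furan-3-yl and thiophen-3-yl cannot be told apart on this aromatic carbon with the chloro core. With thiophen-3-yl kept, the exchange of fluoro for chloro gives a number no lower from compound 1 to compound 4 (the limit leaves the size open), and every chloro compound shown stands at the same ceiling: the limit of > 50000 nM in this assay, at which 3 of the 4 values shown sit.

On these data alone, how far compound 2, compound 3 and compound 4 lie beyond that limit, and so whether the ring exchanges change the number at all, stays open. Also open, as far as these compounds go, is whether an amine or a longer alkyl chain in place of thiophen-3-yl on this carbon would give an exact value in this assay.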